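The source may report more compounds than this note shows. Statements on the series, on what has been measured and on what is new or still open speak of the compounds shown alone.

In a functional assay on A-375 cells (Homo sapiens) for activation, with a stated time of 3 days (a lower number here means that less compound is needed, a higher number that more compound is needed for the effect), three compounds sharing a core have been tested. Compound 1 `O=C(Nc1ccc(-c2cscn2)cc1)C1CCCN(S(=O)(=O)c2ccc(F)c(F)c2)C1` gives > 20000 nM, which is a limit of the assay and not a number. Compound 2 `O=C(Nc1ccc(-c2cscn2)cc1)C1CCCN(Cc2cccnc2)C1` gives > 20000 nM, also a limit. Going by the values given here, compound 3 `O=C(Nc1ccc(-c2ccccc2)cc1)C1CCCN(Cc2ccc(F)c(F)c2)C1` gives 5000 nM, the only true number among the three. Compound 4 `O=C(Nc1ccc(-c2ccoc2)cc1)C1CCCN(Cc2ccc(F)c(F)c2)C1` carries furan-3-yl in place of phenyl on an aromatic carbon, para to a large group. Among the compounds with values here, no measured pair shows a change of this kind, so compound 3 at 5000 nM is the sole anchor. The expected step of a 1.3-fold higher number from compound 3 to compound 4 (0.11 log units; within the scatter) is small and stays within the usual scatter. For compound 4 the estimated value is 6500 nM, with an expected range from 2500 nM to 18000 nM.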

Compound 4, half-maximal effective concentration: 3000 nM
Compound 4: the middle estimate sits 2.2-fold (0.34 log units) above what was measured; the range from low to high includes it.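

The result in this assay is a 1.7-fold lower number from compound 3 to compound 4 (0.22 log units; within the scatter) and so gives no readable difference between the two groups. This aromatic carbon, para to a large group, therefore accepts furan-3-yl as well as phenyl, although the new ring is smaller and carries a hydrogen-bond acceptor. This holds with the rest of the molecule unchanged.

On these data alone, whether an amine or a carboxylic acid would be accepted on this carbon stays open. Only compound 3 and compound 4 give true numbers, and the others stand at a limit of the assay: the limit of > 20000 nM in this assay, at which 2 of the 4 values shown sit.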